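The source may report more compounds than this note shows. Statements on the series, on what has been measured and on what is new or still open speak of the compounds shown alone.

Measured so far in an ADME assay (liver) for metabolic stability, with Liver microsome (Homo sapiens) as the target, read by LC-MS, using microsomes, tested at 1 uM; on this read-out lower numbers stand for a shorter-lived compound and higher numbers for a longer-lived compound:
- compound 1 `C/C(=N/c1ccnc2cc(Cl)ccc12)NC1CCN(C(C)C)CC1`: > 1 h
- compound 2 `CCN(CC)CCN/C(C)=N\c1ccnc2cc(Cl)ccc12`: 0.433 h

Going by the values given here, compound 2, at 0.433 h, holds the only exact number in this assay. For compound 1, the entry > 1 h is a limit of the assay and not a number.

Compound 3 `C/C(=N/c1ccnc2cc(Cl)ccc12)NC1CCN(C)CC1` carries 1-methylpiperidin-4-yl in place of the 2-(diethylamino)ethyl of compound 2 on an amine nitrogen: 1-methylpiperidin-4-yl in place of 2-(diethylamino)ethyl on an amine nitrogen. Among the compounds with values here, no measured step between two compounds differing in one place is available. Within the data shown here, the only guide is compound 1, which also has a six-membered non-aromatic ring on that nitrogen and reports the limit > 1 h.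

A longer half-life, modestly beyond the scatter, is therefore expected, and the estimate is a 2.3-fold higher number from compound 2 to compound 3 (0.36 log units; beyond the scatter). For compound 3 the expected half-life is 1 h, with an estimated range of 0.5 h to 2 h.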

Compound 3, half-life: > 1 h
Compound 3 gave a limit, no number; the forecaster's own chance of this, stated with the estimate: 45%; the middle value lies on the limit itself.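

In this assay, going by these compounds alone, 1-methylpiperidin-4-yl in place of 2-(diethylamino)ethyl on an amine nitrogen gives an at least 2.3-fold higher number from compound 2 to compound 3 (0.36 log units; beyond the scatter), the first readable one-place comparison at this position and evidence that a ring-bearing group here can outlast the open chain. Compound 3 gives > 1 h, which is a limit of the assay and not a number. Methyl against isopropyl on the ring amine nitrogen cannot be read, because compound 1 and compound 3 both stop at a limit: the limit of > 1 h in this assay, at which 2 of the 3 values shown sit.

The true size of the step from the open chain to the ring, and any ordering of the methyl and isopropyl groups, remain unresolved. Also open, from the compounds shown here alone, is whether the longer half-life persists with cyclohexyl, which has no ring nitrogen, or with a five-membered 1-methylpyrrolidin-3-yl ring on that nitrogen.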